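This account rests on a few compounds, and the source may have more. Where it says the series, first, only, none or still open, it means among the compounds named here.

Measured so far:
compound 1 `Cc1cc([N+](=O)[O-])c2cc(-c3nn[nH]n3)cnc2c1C` — 25 mg/kg
compound 2 `O=c1c(-c2nn[nH]n2)c[nH]c2c(C(F)(F)F)cccc12` — > 25 mg/kg

In a functional assay on the whole organism (strain Sprague-Dawley) for inhibition, with Rattus norvegicus as the target (on this read-out lower numbers stand for an effect already at smaller amounts and higher numbers for an effect only at larger amounts of compound), compound 1 gives 25 mg/kg. For compound 2 the entry is only a limit of the assay, > 25 mg/kg. Compound 2 thus sits at the limit of > 25 mg/kg in this assay, at which 1 of the 2 values shown sits, and carries no number of its own. Compound 3 `CC(C)Oc1cccc2c(=O)c(-c3nn[nH]n3)c[nH]c12` differs from compound 2 by isopropoxy in place of trifluoromethyl on an aromatic carbon. Within the data shown here, no measured pair covers such a change, so the step that the limit leaves unreadable from compound 2 to compound 3 is expected to be none beyond the scatter. Compound 3 is therefore estimated at 30 mg/kg, within 10 mg/kg to 100 mg/kg, with a fair chance that again only a limit is reported.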

Compound 3, minimum effective dose: 1.25 mg/kg
The estimate for compound 3 lay 24-fold (1.38 log units) above the measured number; measured number below the stated range.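

In this assay, isopropoxy in place of trifluoromethyl gives an at least 20-fold lower number from compound 2 to compound 3 (1.30 log units; beyond the scatter) on this aromatic carbon, so the read-out depends strongly on the group held here. The true size of this step cannot be read, as compound 2 stands only as a limit of the assay: the limit of > 25 mg/kg in this assay, at which 1 of the 3 values shown sits.

The compounds shown leave open whether the step follows the oxygen or the branched carbons of isopropoxy; methoxy, a hydroxyl or an amine on this carbon would separate them. Among these compounds, compound 1 differs from both others in more than one place and adds no step.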